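The source may hold more compounds than are shown below. What is called first, only, known or untested is meant among the compounds shown, and "the series" means these compounds.

Measured compounds:
- compound 1, `Cc1n[nH]cc1-c1cccc2c1CCC2c1ncc[nH]1`, gives 634 nM
- compound 2, `Cn1ccc(-c2cccc3c2CCC3c2ncc[nH]2)n1`, gives > 10000 nM, a limit of the assay
- compound 3, `Cc1c(OCC2=NCCN2)ccc(Cl)c1NS(C)(=O)=O`, gives > 10000 nM, a limit of the assay

In a functional assay on CHO cells for agonist activity at Alpha-1D adrenergic receptor (Homo sapiens), read by FLIPR and calcium flux (a higher number here means that more compound is needed for the effect, a lower number that less compound is needed), compound 1 gives 634 nM. Compound 2 gives only a limit in this assay, > 10000 nM. Compound 3 likewise gives only a limit, > 10000 nM. Among the measured compounds shown here, compound 2 therefore stands at the weak end of the three values shown, together with compound 3, while compound 1 is the only compound with a number. For the measured compounds named here, the one step that joins two measured compounds runs an at least 15-fold higher number from compound 1 to compound 2 (1.19 log units; beyond the scatter), so exchanging one pyrazolyl for another on the core of compound 1 costs a large amount of activity; how much is unknown because the limit of > 10000 nM in this assay, at which 2 of the 3 values shown sit, caps the value of compound 2.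

Compound 4, `c1cncc(-c2cccc3c2CCC3c2ncc[nH]2)c1`, differs from compound 2 in one place: pyridin-3-yl in place of 1-methyl-1H-pyrazol-3-yl on an aromatic carbon. Going by the values given here, no measured step covers a pyridin-3-yl at this position, and the only step that bears on it shows that the substituent at this carbon can move the value from a measured number to a limit. The expectation for compound 4 in this assay is therefore a value near or at the limit, estimated at 7000 nM, within 1500 nM to 20000 nM. This corresponds to an expected step of an at least 1.4-fold lower number from compound 2 to compound 4 (0.15 log units; that floor lies within the scatter).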

Compound 4, half-maximal effective concentration: > 10000 nM
Compound 4 was reported as a limit (the forecaster's own chance of this, stated with the estimate: 50%); middle value at least 1.4-fold (0.15 log units) from the limit.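

Replacing 3-methyl-1H-pyrazol-4-yl with pyridin-3-yl on this aromatic carbon gives an at least 15-fold higher number from compound 1 to compound 4 (1.19 log units; beyond the scatter) in this assay and so shows that the loss seen with 1-methyl-1H-pyrazol-3-yl is not confined to that one group. Compound 4 gives > 10000 nM, which is a limit of the assay, so a six-membered aromatic ring with 1 hetero atom fares no better here than the five-membered ring of compound 2, and among the compounds on this core only compound 1 keeps a measured number. The step between compound 2 and compound 4 cannot be read, because both sit at the same limit: the limit of > 10000 nM in this assay, at which 3 of the 4 values shown sit.

Going by these compounds, how far compound 2 and compound 4 actually lie beyond that limit, and whether they differ at all, stays open. Also open, on these data alone, is whether a 1H-pyrazol-4-yl without the methyl, or a pyridin-3-yl carrying a methyl or an amine, would bring this carbon back to a measured number, and so which part of the 3-methyl-1H-pyrazol-4-yl of compound 1 matters.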